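Aryl group exchange on the ring nitrogen

This account rests on a few compounds, and the source may have more. Where it says the series, first, only, none or still open, it means among the compounds named here.

Three measured compounds share one core and differ only in the aryl group on the ring nitrogen. Compound 1 `Cn1ncc2c(NC(=O)NCc3cc(C(F)(F)F)nn3-c3cccc(Cl)c3)cccc21` gives 2.3 nM in an assay on CHO-K1 cells for antagonist activity at transient receptor potential cation channel subfamily V member 1 (Homo sapiens), read by FLIPR and calcium flux, with a stated time of 6 min; on this read-out higher numbers stand for weaker inhibition and lower numbers for stronger inhibition. Compound 2 `Cn1ncc2c(NC(=O)NCc3cc(C(F)(F)F)nn3-c3cccc(F)c3)cccc21` gives 7 nM in this assay, and compound 3 `Cn1ncc2c(NC(=O)NCc3cc(C(F)(F)F)nn3-c3ccc(C(C)(C)C)cc3)cccc21` gives 13.2 nM. Compound 3 stands at the highest number of the three; its gap to compound 2 lies within the scatter, while its gap to compound 1 lies beyond it. The measured steps are a 3.0-fold higher number from compound 1 to compound 2 (0.48 log units; beyond the scatter), a 5.7-fold higher number from compound 1 to compound 3 (0.76 log units; beyond the scatter) and a 1.9-fold higher number from compound 2 to compound 3 (0.28 log units; within the scatter).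

Compound 4 `Cn1ncc2c(NC(=O)NCc3cc(C(F)(F)F)nn3-c3ccc(F)c(F)c3)cccc21` is not yet measured in this assay. The change from compound 3 is 3,4-difluorophenyl in place of 4-(tert-butyl)phenyl on an aromatic nitrogen. The step of a 1.9-fold higher number from compound 2 to compound 3 (0.28 log units; within the scatter) bears most directly on it, as compound 4 also carries fluorine on the phenyl, and the step of a 5.7-fold higher number from compound 1 to compound 3 (0.76 log units; beyond the scatter) shows that a 3-chlorophenyl gives a lower number still. Among the compounds with values here, the second fluorine has no precedent among the measured compounds, so its own contribution is unknown. Compound 4 is therefore expected to return toward the numbers of compound 2 and compound 1, with an expected step of a 2.6-fold lower number from compound 3 to compound 4 (0.42 log units; beyond the scatter). The estimate for compound 4 is 5 nM, with a range from 1.5 nM to 15 nM.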

Compound 4, inhibition constant: 4.9 nM
Compound 4: the middle estimate sits 1.0-fold (0.01 log units) above what was measured; measured number inside the range.
By their numbers in this assay, from the lowest: compound 1; then compounds 4, 2 and 3 (each within the scatter of the next, the first and the last beyond it).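

In this assay, 3,4-difluorophenyl in place of 4-(tert-butyl)phenyl on the aromatic nitrogen gives a 2.7-fold lower number from compound 3 to compound 4 (0.43 log units; beyond the scatter), the first step away from compound 3 to a fluorinated aryl group that lies beyond the scatter. Within the data shown here, the second fluorine, which had no precedent, can now be read directly: adding it gives a 1.4-fold lower number from compound 2 to compound 4 (0.15 log units; within the scatter), so this single addition cannot be told apart from repeat-measurement noise. Even with two fluorines the aryl group does not match 3-chlorophenyl, with a 2.1-fold higher number from compound 1 to compound 4 (0.33 log units; beyond the scatter), so compound 1 remains the most potent of the four, and no accompanying measurement offers an explanation for these steps.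

The compounds shown leave open whether the advantage of compound 1 belongs to chlorine itself, which a 3,4-dichlorophenyl or a 3-chloro-4-fluorophenyl group on the same nitrogen would test. They also leave open how this position responds to aryl groups carrying something other than halogen or tert-butyl, such as a methoxy group, a nitrile or an amine.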